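Alkoxy chain swap on the pyridine urea series

A few compounds are considered here, and "the series" means these few. Any claim that something is new, unique, unknown or untested is made for them only; others in the source may bear on it.

Of the compounds shown here, three have been measured in a functional assay on CHO cells for antagonist activity at sphingosine 1-phosphate receptor 2 (Homo sapiens), read by scintillation counting and GTPgammaS binding, with a stated time of 4 h, in the presence of a further agent that is not named here; a lower number here means a stronger inhibitor, a higher number a weaker inhibitor. Compound 1 `Cc1cc(NNC(=O)Nc2cc(Cl)nc(Cl)c2)ncc1-c1ccn(C)n1` gives 9.3 nM. Compound 2 `Cc1cc(CNC(=O)Nc2cc(Cl)nc(OCC(F)F)c2)nnc1-c1cn(C)nc1C(F)(F)F` gives 36 nM, which is the second highest number of the three, beyond the scatter from compound 1 and beyond the scatter from compound 3. Compound 3 `CCOc1cc(NC(=O)NCc2cc(C)c(-c3cn(C)nc3C(F)(F)F)nn2)cc(C)n1` gives 242 nM; compound 3 differs from compound 2 in more than one place, so its number is noted only for comparison.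

Compound 4 `COCCOc1cc(NC(=O)NCc2cc(C)c(-c3cn(C)nc3C(F)(F)F)nn2)cc(Cl)n1` is not yet measured. It differs from compound 2 by methoxymethyl in place of difluoromethyl on a saturated chain carbon bound to an oxygen on an aromatic ring; the rest of the molecule is unchanged. Going by the values given here, no measured pair in this set isolates such a chain change, so there is no direct guide to its size. The expectation is a step in this assay from compound 2 to compound 4 of a 1.3-fold higher number from compound 2 to compound 4 (0.10 log units; within the scatter), that is, no change clearly beyond the scatter, with a slight lean toward a higher number. Compound 4 is therefore estimated at 45 nM in this assay, within a range of 15 nM to 140 nM.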

Compound 4, half-maximal inhibitory concentration: 640 nM
Beside the measured number, compound 4's estimate is 14-fold (1.15 log units) below it; measured number outside the range, above it.
By their numbers in this assay, from the lowest: compound 1; then compound 2; then compound 3; then compound 4.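

In this assay, replacing 2,2-difluoroethoxy with 2-methoxyethoxy gives an 18-fold higher number from compound 2 to compound 4 (1.25 log units; beyond the scatter), so this chain position responds strongly to the choice of group even though the leaving and entering groups have the same heavy-atom count. The change swaps fluorine for carbon and oxygen at the chain end and brings in a hydrogen-bond acceptor, and with the rest of the molecule unchanged, the step belongs to this single swap. Nothing measured here bears on the reason for a step of this size.

The compounds shown do not separate the loss of the fluorines from the arrival of the ether oxygen. A 2,2,2-trifluoroethoxy chain, a 3-methoxypropoxy chain or a chain ending in an amine on the same core would each help to separate these.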